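Hexyl to chloropropyl on a weakly active pair

The source may hold more compounds than are shown below. What is called first, only, known or untested is meant among the compounds shown, and "the series" means these compounds.

The compounds are compared in a functional assay on SW-620 cells (Homo sapiens) for antiproliferative activity, read by MTT assay, with a stated time of 72 h; on this read-out higher numbers stand for weaker inhibition and lower numbers for stronger inhibition. Compound 1 `O=c1nc2oc(CCCCl)cc2cn1Cc1cn(-c2ccc(F)cc2)nn1` gives > 100000 nM, which is a limit of the assay rather than a number. Among the compounds with values here, compound 2 `CCCCCCc1cc2cn(Cc3cn(Cc4ccccc4)nn3)c(=O)nc2o1` is the only compound with a number, giving 93500 nM in this assay. Within the data shown here, the only other value shown, that of compound 1, is a limit, (the limit of > 100000 nM in this assay, at which 1 of the 2 values shown sits). Compound 3 `O=c1nc2oc(CCCCl)cc2cn1Cc1cn(Cc2ccccc2)nn1` is not yet measured. It differs from compound 2 by chloro in place of propyl on a saturated chain carbon, three bonds along the chain from an aromatic carbon. No step between measured compounds is available, so nothing shown says which way this change pulls. Compound 3 carries the same chain as compound 1 and the same benzyl group as compound 2, and both of those measured compounds sit at the top of the range shown. The step is expected to be none beyond the scatter, a 1.1-fold higher number from compound 2 to compound 3 (0.03 log units; within the scatter). Compound 3 is accordingly estimated at 100000 nM, between 40000 nM and 300000 nM, with a fair chance that only a limit is reported.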

Compound 3, half-maximal inhibitory concentration: 75500 nM
For compound 3 the middle estimate is 1.3-fold (0.12 log units) above the measured one; the measured number falls inside the stated range.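

In this assay, hexyl to 3-chloropropyl gives a 1.2-fold lower number from compound 2 to compound 3 (0.09 log units; within the scatter), so on this read-out the two chains cannot be told apart when benzyl is held constant. Benzyl in place of 4-fluorophenyl on an aromatic nitrogen gives an at least 1.3-fold lower number from compound 1 to compound 3 (0.12 log units; that floor lies within the scatter), which does not show whether this change matters. Compound 1 carries a limit of the assay, so this step is a floor and not a measured size: the limit of > 100000 nM in this assay, at which 1 of the 3 values shown sits.

From the compounds shown here alone, whether an amine or a carboxylic acid at the end of this chain would bring the number out of this weak range remains open. Also open, going by these compounds, is whether hexyl and 3-chloropropyl would still be indistinguishable with 4-fluorophenyl in place of benzyl.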